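Swapping cyclopentyl for oxolan-3-yl on the amine

A few compounds are considered here, and "the series" means these few. Any claim that something is new, unique, unknown or untested is made for them only; others in the source may bear on it.

Compound 1 `Clc1ccc(COc2ccc(OCCOCCNC3CCCC3)cc2)cc1`: 7670 nM
Compound 2 `COc1cc(OCCOCCNC2CCCC2)ccc1OCc1ccccc1`: 44600 nM
Compound 3 `c1ccc(COc2ccc(OCCOCCNC3CCCC3)cc2)cc1`: 24800 nM

In a functional assay on SK-OV-3 cells (Homo sapiens) for inhibition, read by CCK-8 assay, with a stated time of 70 h (on this read-out higher numbers stand for weaker inhibition and lower numbers for stronger inhibition), compound 3 gives 24800 nM, the second highest of the three numbers. Its nearest neighbour is compound 2, a 1.8-fold lower number from compound 2 to compound 3 (0.25 log units; within the scatter), a step within the scatter, while the furthest is compound 1, a 3.2-fold higher number from compound 1 to compound 3 (0.51 log units; beyond the scatter), beyond it. Compound 4 `c1ccc(COc2ccc(OCCOCCNC3CCOC3)cc2)cc1` differs from compound 3 in one place: oxolan-3-yl in place of cyclopentyl on an amine nitrogen. Going by the values given here, both measured steps concern substituents on the aromatic carbon, and neither touches the amine nitrogen, so no measured step bears on this change. Compound 4 is therefore expected to stay close to compound 3, with a 1.2-fold higher number from compound 3 to compound 4 (0.08 log units; within the scatter) lying within the scatter. The estimate for compound 4 is 30000 nM, with a range from 10000 nM to 90000 nM.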

Compound 4, half-maximal inhibitory concentration: 48000 nM
The estimate for compound 4 lay 1.6-fold (0.20 log units) below the measured number, within the range that was stated.
By their numbers in this assay, from the lowest: compound 1; then compounds 3, 2 and 4 (each within the scatter of the next).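

On the amine nitrogen, the first position in this series where a change can be read, oxolan-3-yl in place of cyclopentyl gives a 1.9-fold higher number from compound 3 to compound 4 (0.29 log units; within the scatter) in this assay. Exchanging this one ring carbon for oxygen therefore gives a step that cannot be told apart from repeat scatter on this read-out, even though it adds a hydrogen-bond acceptor. Nothing shown offers a reason for this result.

On these data alone, it remains open whether the same exchange would read alike on the chloro-bearing compound 1. Also open, as far as these compounds go, is how the amine nitrogen would respond to a cyclohexyl group, a piperidin-4-yl group or a carboxylic acid on a longer chain.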